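Working notes on a small series and one pending compound

The compounds below may be only part of what the source reports. "The series", "measured", "known", "first", "only" and "open" are said of these compounds alone.

Values in an assay on cells for inhibition of histone deacetylase 8 (Homo sapiens), read by fluorescence, with a stated time of 30 min (on this read-out higher numbers stand for weaker inhibition and lower numbers for stronger inhibition), for the measured compounds:
Compound 1 `O=C1NC(=O)/C(=C\c2ccc(OCC(=O)N3N=C(c4ccccc4)CC3c3ccc(C(F)(F)F)cc3)cc2)S1`: 16000 nM
Compound 2 `O=C1NC(=O)/C(=C\c2ccc(OCC(=O)N3N=C(c4ccccc4)CC3c3ccc(F)cc3)cc2)S1`: 26000 nM
Compound 3 `O=C1NC(=O)/C(=C\c2ccc(OCC(=O)N3N=C(c4ccc(F)cc4)CC3c3ccc(C(F)(F)F)cc3)cc2)S1`: > 50000 nM, a limit of the assay, not a number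

The change from compound 1 to compound 2 is fluoro in place of trifluoromethyl on an aromatic carbon; the step is a 1.6-fold higher number from compound 1 to compound 2 (0.21 log units; within the scatter). Compound 3 differs from compound 1 by fluoro in place of hydrogen on an aromatic carbon, and the step is an at least 3.1-fold higher number from compound 1 to compound 3 (0.49 log units; beyond the scatter), with compound 3 sitting at the limit of > 50000 nM in this assay, at which 1 of the 3 values shown sits.

Compound 4 `O=C1NC(=O)/C(=C\c2ccc(OCC(=O)N3N=C(c4ccc(F)cc4)CC3c3ccc(F)cc3)cc2)S1` is not yet measured. It differs from compound 3 by fluoro in place of trifluoromethyl on an aromatic carbon, the same change as that from compound 1 to compound 2. The expected step is a step that the limit leaves unreadable from compound 3 to compound 4, resting on the earlier step of a 1.6-fold higher number from compound 1 to compound 2 (0.21 log units; within the scatter). Compound 4 is therefore expected at about 80000 nM, most likely reported again only as a limit, with a range of 40000 nM to 200000 nM.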

Compound 4, half-maximal inhibitory concentration: > 50000 nM
Compound 4: a limit, no number; the forecaster's own chance of this, stated with the estimate: 80%; the middle value lies beyond the limit too.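

In this assay compound 4 gives > 50000 nM, a limit of the assay and not a number, so the step from trifluoromethyl to fluoro cannot be read on this core, and the result neither confirms nor refutes that it carries over from the core of compound 1. Fluoro in place of hydrogen gives an at least 1.9-fold higher number from compound 2 to compound 4 (0.28 log units; that floor lies within the scatter), which on its own does not establish a real weakening on the core of compound 2. Set beside the earlier step, this change reads: the same change on two cores in this assay, an at least 3.1-fold higher number (0.49 log units; beyond the scatter) from compound 1 to compound 3 and an at least 1.9-fold higher number (0.28 log units; that floor lies within the scatter) from compound 2 to compound 4; the limit leaves it open whether they differ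

Still open, on these data alone, is how compound 3 and compound 4 compare with each other. Also open, as far as these compounds go, is whether a nitrile or a methoxy group in place of fluoro on either core would give a readable value.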